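Pyridin-4-yl in place of 4-(dimethylamino)phenyl on the hydrazone carbon

This account rests on a few compounds, and the source may have more. Where it says the series, first, only, none or still open, it means among the compounds named here.

Measured so far:
compound 1 `O=C(N/N=C/c1ccc(F)cc1)c1cccnc1Nc1cccc(C(F)(F)F)c1`: 41.3%
compound 2 `CN(C)c1ccc(/C=N/NC(=O)c2cccnc2Nc2cccc(C(F)(F)F)c2)cc1`: 39.5%

In a functional assay on the whole organism (strain Wistar) for inhibition, with Rattus norvegicus as the target, read by paw edema, with a stated time of 3 h, at a dose of 10 mg/kg by the intraperitoneal route (a lower number here means less inhibition, a higher number more inhibition at the dose given (going by the name of the read-out)), compound 1 gives 41.3% and compound 2 gives 39.5%. Among the compounds with values here, compound 2 has the lowest of the two numbers, but its only neighbour, compound 1, lies within the scatter, so no order between them can be stated. Within the data shown here, the sole measured step, a number 1.8 percentage points lower from compound 1 to compound 2 (within the scatter), changed a substituent on the same ring that compound 3 `O=C(N/N=C/c1ccncc1)c1cccnc1Nc1cccc(C(F)(F)F)c1` now replaces: pyridin-4-yl in place of 4-(dimethylamino)phenyl on a carbon with a double bond to nitrogen. That step was within the scatter and bears only loosely on a ring-for-ring exchange, so the expected step of a number 0.5 percentage points higher from compound 2 to compound 3 (within the scatter) is none beyond the scatter. Compound 3 is therefore estimated at 40%, with a range from 27% to 53%.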

Compound 3, a percentage reported as inhibition, in the whole organism at one dose (the size of the read-out at that dose, not a potency): 54.9%
Estimate against measurement, compound 3: 14.9 percentage points below, and the stated range ends below it.
By their numbers in this assay, from the lowest: compounds 2 and 1 (each within the scatter of the next); then compound 3.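

On the carbon with a double bond to nitrogen, exchanging the ring itself moves the read-out in this assay, whereas the earlier substituent change on the phenyl ring did not: pyridin-4-yl gives a number 15.4 percentage points higher from compound 2 to compound 3 (beyond the scatter), and in place of 4-fluorophenyl it gives a number 13.6 percentage points higher from compound 1 to compound 3 (beyond the scatter). Both phenyl compounds lie on the same side of compound 3, so the two steps agree in direction. No measurement bears on the reason for this gain. From the compounds shown here alone, whether pyridin-3-yl or pyridin-2-yl on the same carbon would retain it remains open, as does the reading for a saturated ring such as piperidin-4-yl.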